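Working notes: from isopropoxy to butoxy

The source may hold more compounds than are shown below. What is called first, only, known or untested is meant among the compounds shown, and "the series" means these compounds.

Measured so far in an ADME assay on BJ cells (Homo sapiens) for cytotoxicity, read by luminescence, with a stated time of 72 h (on this read-out lower numbers stand for an effect already at smaller amounts and higher numbers for an effect only at larger amounts of compound), are two compounds:
compound 1 `CCOC(=O)c1c(-c2ccccc2)[nH]c2cc(OC)ccc2c1=O` gives > 21500 nM as a limit
compound 2 `CCOC(=O)c1c(-c2cccc(OC(C)C)c2)[nH]c2cc(OC)ccc2c1=O` gives > 21500 nM as a limit

Among the measured compounds shown here, compound 2 has no number, only a limit, and the series so far rests on the limit of > 21500 nM in this assay, at which 2 of the 2 values shown sit, and nothing else. Compound 3 `CCCCOc1cccc(-c2[nH]c3cc(OC)ccc3c(=O)c2C(=O)OCC)c1` differs from compound 2 by butyl in place of isopropyl on an oxygen on an aromatic ring and so carries butyl in place of isopropyl on an oxygen on an aromatic ring. For the measured compounds named here, the one measured step that bears on this, a step that the two limits leave unreadable from compound 1 to compound 2, has no readable size, so in this assay no step beyond the scatter is expected. The estimated step is a step that the limit leaves unreadable from compound 2 to compound 3 and is expected to stay small. The estimated value of compound 3 is 25000 nM within an expected range of 15000 nM to 45000 nM and here too only a limit is expected.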

Compound 3, half-maximal effective concentration: > 21500 nM
Compound 3: only a limit was reported; the forecaster's own chance of this, stated with the estimate: 85%; the middle value is on the limit's open side.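

No step can be read among compound 1, compound 2 and compound 3, since all three give a limit and not a number: the limit of > 21500 nM in this assay, at which 3 of the 3 values shown sit.

The compounds shown leave open whether hydrogen, isopropoxy and butoxy differ at all on this read-out.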